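Moving the Fluorine on the Pendant Phenyl Ring

The source may report more compounds than this note shows. Statements on the series, on what has been measured and on what is new or still open speak of the compounds shown alone.

Going by the values given here, in an ADME assay on microsomes from liver (Homo sapiens) for metabolic stability, tested at 2.5 uM (on this read-out lower numbers stand for slow clearance and higher numbers for fast clearance), compound 3 `O=S(=O)(c1cccc(F)c1)c1cnc2cc(F)ccc2c1-c1cccc(F)c1` gives 0.24 mL/min, the lowest of the three numbers known here. Compound 1 `O=S(=O)(c1ccc(F)cc1)c1cnc2cc(F)ccc2c1-c1ccc(F)cc1` gives 1.34 mL/min and compound 2 `COc1ccc(-c2c(S(=O)(=O)c3cccc(F)c3)cnc3cc(F)ccc23)cc1` gives 1.89 mL/min in this assay. Among the compounds with values here, the only single-site step measured, a 7.9-fold lower number from compound 2 to compound 3 (0.90 log units; beyond the scatter), concerns a different exchange. Compound 4 `O=S(=O)(c1cccc(F)c1)c1cnc2cc(F)ccc2c1-c1ccc(F)cc1` differs from compound 3 in one place: 4-fluorophenyl in place of 3-fluorophenyl on an aromatic carbon. Within the data shown here, no measured step tests this exact swap; compound 1 and compound 3 differ in two places, so their values only suggest that a 4-fluorophenyl may go with a higher number. Compound 4 is therefore expected to sit between those two, with an upward step of a 2.9-fold higher number from compound 3 to compound 4 (0.46 log units; beyond the scatter) that may or may not exceed the scatter. The estimate for compound 4 is 0.7 mL/min, within 0.25 mL/min to 2 mL/min.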

Compound 4, intrinsic clearance in a liver preparation (reported as CLH), per the amount of preparation that the assay uses: 0.11 mL/min
For compound 4 the middle estimate is 6.4-fold (0.80 log units) above the measured one, and the stated range ends above it.
By their numbers in this assay, from the lowest: compound 4; then compound 3; then compounds 1 and 2 (each within the scatter of the next).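

In this assay, 4-fluorophenyl in place of 3-fluorophenyl on this aromatic carbon gives a 2.2-fold lower number from compound 3 to compound 4 (0.34 log units; beyond the scatter), so the read-out depends on where the fluorine sits, even with the same atoms. Fluoro in place of methoxy on that ring gives a 17-fold lower number from compound 2 to compound 4 (1.24 log units; beyond the scatter), while on the sulfonyl sulfur, 3-fluorophenyl in place of 4-fluorophenyl gives a 12-fold lower number from compound 1 to compound 4 (1.09 log units; beyond the scatter), so the preferred fluorine placement differs between the two rings. Nothing here explains these shifts. As far as these compounds go, what a chloro, a nitrile or an amine would do on the ring at this aromatic carbon remains open.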